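Methoxy in Place of Methyl on a Scaffold at the Limit

The compounds below may be only part of what the source reports. "The series", "measured", "known", "first", "only" and "open" are said of these compounds alone.

Compound 1 `COc1ccc(-c2c(C=O)c3cc(C#N)c(C#N)cc3n2OC)cc1`: > 100000 nM
Compound 2 `COn1c(-c2ccccc2)c(CO)c2cc(C#N)c(C#N)cc21`: > 100000 nM
Compound 3 `COn1c(-c2ccc(C)cc2)c(CO)c2cc(C#N)c(C#N)cc21`: > 100000 nM

In an assay on isolated protein for inhibition of Amine oxidase [flavin-containing] B (Homo sapiens), read by fluorescence and spectrophotometry, with a stated time of 20 min (on this read-out lower numbers stand for stronger inhibition and higher numbers for weaker inhibition), compound 1 gives > 100000 nM, which is a limit of the assay and not a number. Compound 2 likewise gives only the limit > 100000 nM. Compound 3 also stands at the limit, > 100000 nM. Within the data shown here, the measured step that the two limits leave unreadable from compound 2 to compound 3 is thus unreadable, and every value so far sits at one point: the limit of > 100000 nM in this assay, at which 3 of the 3 values shown sit.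

Compound 4 `COc1ccc(-c2c(CO)c3cc(C#N)c(C#N)cc3n2OC)cc1` differs from compound 3 by methoxy in place of methyl on an aromatic carbon. Among the measured compounds shown here, no measured step bears directly on this change, and nothing among the values shown hints at a move away from the limit. The expected step is a step that the limit leaves unreadable from compound 3 to compound 4, none beyond the scatter. Compound 4 is estimated at 150000 nM, with a range from 50000 nM to 500000 nM.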

Compound 4, half-maximal inhibitory concentration: > 100000 nM
Compound 4 was reported as a limit; the forecaster's own chance of this, stated with the estimate: 85%; the middle value does not contradict the limit.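

Compound 4 gives > 100000 nM as a limit of the assay and not a number. Among these compounds, no step to compound 4 from compound 1, compound 2 or compound 3 can be read. The compounds shown leave open whether any change on this core would bring a value away from the limit.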